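Two Chloro Groups on the Shared Core

The source may report more compounds than this note shows. Statements on the series, on what has been measured and on what is new or still open speak of the compounds shown alone.

Compound 1, `ClCc1ccc(Cn2cnc3c(Cl)ncnc32)cc1`: in a functional assay on IGROV-1 cells (Homo sapiens) for cytotoxicity, read by sulforhodamine B assay, with a stated time of 48 h (a lower number here means that less compound is tolerated, a higher number that more compound is tolerated), compound 1 gives > 100000 nM, which is a limit of the assay and not a number.
Compound 2, `ClCc1cccc(Cn2cnc3c(Cl)nc(Cl)nc32)c1`: in this assay compound 2 gives 20000 nM.
Compound 3, `Nc1nc(Cl)c2ncn(Cc3ccccc3CCl)c2n1`: in this assay compound 3 gives > 100000 nM, again only a limit.

Compound 1 therefore stands at a limit: the cells tolerated the highest concentration tested, and no exact number is known. Such a result is the common outcome here, because of the limit of > 100000 nM in this assay, at which 2 of the 3 values shown sit. Compound 2 alone gives a number.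

Compound 4, `ClCc1ccc(Cn2cnc3c(Cl)nc(Cl)nc32)cc1`, is not yet measured. It differs from compound 1 in a single place: chloro in place of hydrogen on an aromatic carbon. Among the measured compounds shown here, no two measured compounds differ in only one place, so no measured step of this kind exists.

Still, compound 2 also carries two chloro groups on its core and gives a number where compound 1 gives a limit, so compound 4 is expected to move toward measurable toxicity, a step of an at least 3.3-fold lower number from compound 1 to compound 4 (0.52 log units; beyond the scatter) from the limit. Compound 4 is estimated at 30000 nM, with a range from 10000 nM to 100000 nM, and a real chance remains that only a limit is reported.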

Compound 4, concentration lethal to 50% of the cells: 60300 nM
Estimate against measurement, compound 4: 2.0-fold (0.30 log units) below; the measured number falls inside the stated range.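

In this assay, among the compounds shown here, placing chloro instead of hydrogen on the aromatic carbon between two ring nitrogen atoms gives the first measured step at this position, a step of an at least 1.6-fold lower number from compound 1 to compound 4 (0.21 log units; that floor lies within the scatter). Since this is only a floor, it does not by itself show a change beyond the usual scatter. What it does show is that this single change yields a number in compound 4 where compound 1 sits at a limit, an outcome that is common in this set: the limit of > 100000 nM in this assay, at which 2 of the 4 values shown sit.

Going by these compounds, the exact value of compound 1 remains unknown, so the full size of the step stays open. The compounds shown also leave open whether a bromo or a methoxy group in this same place would give a number.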